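The source may report more compounds than this note shows. Statements on the series, on what has been measured and on what is new or still open speak of the compounds shown alone.

Measured compounds in an ADME assay on HepG2 cells (Homo sapiens) for cytotoxicity, read by luminescence, CellTiter-Glo and ATP content, with a stated time of 72 h; on this read-out higher numbers stand for an effect only at larger amounts of compound and lower numbers for an effect already at smaller amounts:
compound 1 `COc1cccc(CNCCCNc2ccnc3cc(Oc4ccc(Cl)cc4)ccc23)c1O`: compound 1 gives 5700 nM
compound 2 `COc1ccc(F)cc1CNCCCNc1ccnc2cc(CCc3ccccc3)ccc12`: compound 2 gives 4240 nM
compound 3 `COc1ccc(F)cc1CNCCCNc1ccnc2cc(Oc3ccc(C(C)(C)C)cc3)ccc12`: compound 3 gives 7200 nM

Compound 1 stands second highest of the three numbers. Compound 3 is nearest to it and compound 2 furthest, and both gaps lie within the scatter, so the three measured values are not separated from one another in this assay.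

Compound 4 `COc1cccc(CNCCCNc2ccnc3cc(Cc4ccc(C#N)cc4)ccc23)c1O` differs from compound 1 by 4-cyanobenzyl in place of 4-chlorophenoxy on an aromatic carbon. For the measured compounds named here, no measured pair exchanges 4-chlorophenoxy for 4-cyanobenzyl. Going by the values given here, the one measured step at the same aromatic carbon of the core is a 1.7-fold higher number from compound 2 to compound 3 (0.23 log units; within the scatter), which swapped one side group for another without moving the number beyond the scatter. On that basis the exchange on the core is expected to leave this assay much where it is for compound 1, with no step beyond the scatter, giving an expected 1.0-fold lower number from compound 1 to compound 4 (0.02 log units; within the scatter). Compound 4 is therefore estimated at 5500 nM, with an expected range from 2500 nM to 12000 nM.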

Compound 4, half-maximal effective concentration: 7150 nM
Beside the measured number, compound 4's estimate is 1.3-fold (0.11 log units) below it, and the stated range covers the measured number.
By their numbers in this assay, from the lowest: compounds 2, 1, 4 and 3 (each within the scatter of the next).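

In this assay, for the compounds shown here, the exchange of 4-chlorophenoxy for 4-cyanobenzyl gives a 1.3-fold higher number from compound 1 to compound 4 (0.10 log units; within the scatter), a first single-place step at this aromatic carbon with the rest of compound 1 held fixed. Together with a 1.7-fold higher number from compound 2 to compound 3 (0.23 log units; within the scatter), this makes two exchanges at this carbon, on two different backgrounds, and neither moves the number beyond the scatter. No supporting measurement is available to explain this result.

Every side group shown at this carbon keeps a six-membered aromatic ring, so it remains open whether a carboxylic acid, an amine or a plain alkyl chain there would shift the number beyond the scatter. Also open, going by these compounds, is how the number responds to single changes elsewhere in the molecule, away from this carbon.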